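The source may report more compounds than this note shows. Statements on the series, on what has been measured and on what is new or still open speak of the compounds shown alone.

Compound 1, `ClCc1ccccc1Cn1cnc2c(Cl)ncnc21`, gives 3090 nM in a functional assay on EKVX cells (Homo sapiens) for cytotoxicity, read by sulforhodamine B assay, with a stated time of 48 h; on this read-out higher numbers stand for weaker inhibition of growth and lower numbers for stronger inhibition of growth.
Compound 2, `ClCc1cccc(Cn2cnc3ncnc(Cl)c32)c1`, gives 13800 nM in this assay.
Compound 3, `ClCc1cccc(Cn2cnc3c(Cl)ncnc32)c1`, gives 18600 nM in this assay.

Among these three, compound 2 stands second highest. Its nearest neighbour is compound 3, whose number is higher by an amount that lies within the scatter, so the two cannot be told apart. Among the measured compounds shown here, compound 1 sits furthest away, with a lower number that lies beyond the scatter; no counted step between compound 1 and compound 2 exists here, so only what the two values show is stated.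

Compound 4, `ClCc1cccc(Cn2cnc3nc(Cl)nc(Cl)c32)c1`, has not yet been measured in this assay. It differs from compound 2 in one place: chloro in place of hydrogen on an aromatic carbon. For the measured compounds named here, no measured pair shows this change, so its effect cannot be read from the data. Without such a precedent the plainest expectation is a step of no size beyond the scatter, in no fixed direction. Compound 4 is therefore expected to give 12000 nM, with a range from 4000 nM to 40000 nM. This estimate is expected to mean a 1.2-fold lower number from compound 2 to compound 4 (0.06 log units; within the scatter).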

Compound 4, concentration for 50% growth inhibition: 930 nM
Compound 4: the middle estimate sits 13-fold (1.11 log units) above what was measured; measured number below the stated range.
By their numbers in this assay, from the lowest: compound 4; then compound 1; then compounds 2 and 3 (each within the scatter of the next).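

Putting chloro in place of hydrogen on the aromatic carbon between two ring nitrogen atoms brings a 15-fold lower number from compound 2 to compound 4 (1.17 log units; beyond the scatter) in this assay and so marks the step as large. Compound 1, compound 2 and compound 3 all keep hydrogen on this carbon, so only now does it appear that this position can respond strongly to a change, here the entry of a single chlorine with no ring, hydrogen-bond donor or acceptor added. Nothing measured in this set accounts for the size of the step. From the compounds shown here alone, whether an amine, a methoxy group or a bromo group on this carbon would give a step of similar size remains open. So does whether chloro here would act in the same way on the scaffolds of compound 1 and compound 3.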